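The compounds below may be only part of what the source reports. "The series", "measured", "known", "first", "only" and "open" are said of these compounds alone.

Measured in a physicochemical assay for solubility, read by HPLC, using the shake flask method, in phosphate buffer, with a stated time of 20 h, at pH 6.5; a higher number here means a more soluble compound, a lower number a less soluble compound:
Compound 1 `CN1CCN(C2CCN(c3nccc4[nH]c(-c5ccc(F)c(C(F)(F)F)c5)nc34)CC2)CC1`: 195000 nM
Compound 2 `CN1CCN(C2CCN(c3nccc4[nH]c(-c5cc(F)cc(F)c5)nc34)CC2)CC1`: 200000 nM
Compound 3 `CN1CCN(C2CCN(c3nccc4[nH]c(C5CCCC5)nc34)CC2)CC1`: 170000 nM

These three values lie within the usual scatter of each other, so compound 2 stands level with compound 1 and compound 3, not apart from them. The unmeasured compound 4 `CC(C)(C)N1CCN(CC2CCN(c3nccc4[nH]c(-c5cc(F)cc(F)c5)nc34)CC2)CC1` alters compound 2 at a new place, on a saturated ring carbon of a six-membered non-aromatic ring with 1 nitrogen. There, (4-(tert-butyl)piperazin-1-yl)methyl comes in place of 4-methylpiperazin-1-yl ((4-(tert-butyl)piperazin-1-yl)methyl in place of 4-methylpiperazin-1-yl on a saturated ring carbon).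

Three measured steps are available, and all of them swap a group on an aromatic carbon: a 1.0-fold higher number from compound 1 to compound 2 (0.01 log units; within the scatter), a 1.1-fold lower number from compound 1 to compound 3 (0.06 log units; within the scatter) and a 1.2-fold lower number from compound 2 to compound 3 (0.07 log units; within the scatter). Each is within the scatter, so that swap moved this assay by no more than repeat measurements would. None of these steps touches the saturated ring carbon, which leaves the size of the new step without direct evidence. The expectation therefore starts from compound 2 at 200000 nM and allows only a modest move towards a lower number, with a wide range. The expected step is estimated as a 1.5-fold lower number from compound 2 to compound 4 (0.19 log units; within the scatter). Compound 4 is expected at an estimated 130000 nM, within an estimated range of 50000 nM to 230000 nM.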

Compound 4, solubility: 185000 nM
Estimate against measurement, compound 4: 1.4-fold (0.15 log units) below; the range from low to high includes it.
By their numbers in this assay, from the lowest: compounds 3, 4, 1 and 2 (each within the scatter of the next).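

In this assay, for the compounds shown here, the first step at the saturated ring carbon is a 1.1-fold lower number from compound 2 to compound 4 (0.03 log units; within the scatter), so the two compounds cannot be told apart here. The earlier steps shown here showed such a flat reading only for swaps on an aromatic carbon, and this one shows it at a second place in the molecule, with (4-(tert-butyl)piperazin-1-yl)methyl, a group of more heavy atoms, in place of 4-methylpiperazin-1-yl. Nothing at hand explains why the numbers stay level across these compounds.

The new group brings in the tert-butyl and the extra methyl link together, so the compounds shown cannot separate what each does alone, and a single step at this position cannot show how far the level reading extends. All four compounds carry a piperazine on the saturated ring, which leaves open how this read-out would respond to a different group there, such as a morpholine or a carboxylic acid.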